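A few compounds are considered here, and "the series" means these few. Any claim that something is new, unique, unknown or untested is made for them only; others in the source may bear on it.

In an assay on isolated protein with Bile acid receptor (Homo sapiens) as the target (a higher number here means that more compound is needed for the effect, a lower number that less compound is needed), the three measured compounds gave the following numbers:

compound 1 `COC(=O)/C=C/c1cccc(N(Cc2ccc(/C=C/c3cccc(C(F)(F)F)c3)cc2)C(=O)C(C)C)c1`: 267 nM
compound 2 `COC(=O)/C=C/c1cccc(N(Cc2ccc(/C=C/c3cccc(F)c3)cc2)C(=O)C(C)C)c1`: 71 nM
compound 3 `COC(=O)/C=C/c1cccc(N(Cc2ccc(/C=C/c3ccc(F)cc3)cc2)C(=O)C(C)C)c1`: 120 nM

Compound 3 holds the second highest of these three numbers; its nearest neighbour is compound 2, with a 1.7-fold higher number from compound 2 to compound 3 (0.23 log units; within the scatter), and its furthest is compound 1, with a 2.2-fold lower number from compound 1 to compound 3 (0.35 log units; beyond the scatter). Compound 4 `COC(=O)/C=C/c1cccc(N(Cc2ccc(/C=C/c3ccccn3)cc2)C(=O)C(C)C)c1` differs from it by pyridin-2-yl in place of 4-fluorophenyl on a double-bonded chain carbon bound to a double-bonded chain carbon. Within the data shown here, no measured step swaps the ring itself; the steps of a 3.8-fold lower number from compound 1 to compound 2 (0.58 log units; beyond the scatter) and a 2.2-fold lower number from compound 1 to compound 3 (0.35 log units; beyond the scatter) only exchange substituents on that ring, and all were modest. The estimate for compound 4 therefore leans on the spread of the three numbers rather than on a direct precedent, and a step of a 1.7-fold higher number from compound 3 to compound 4 (0.22 log units; within the scatter) is expected, with the number for compound 4 estimated at 200 nM within a range from 60 nM to 700 nM.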

Compound 4, half-maximal effective concentration: 310 nM
Beside the measured number, compound 4's estimate is 1.6-fold (0.19 log units) below it; low and high end bracket the measured number.
By their numbers in this assay, from the lowest: compounds 2 and 3 (each within the scatter of the next); then compounds 1 and 4 (each within the scatter of the next).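

In this assay, this position, until now held only by substituted phenyl rings, takes a ring with a hetero atom in compound 4, and pyridin-2-yl gives a 2.6-fold higher number from compound 3 to compound 4 (0.41 log units; beyond the scatter) and a 4.4-fold higher number from compound 2 to compound 4 (0.64 log units; beyond the scatter), so neither fluorophenyl group is matched. Against 3-(trifluoromethyl)phenyl the exchange gives a 1.2-fold higher number from compound 1 to compound 4 (0.06 log units; within the scatter), which leaves those two groups indistinguishable here. Nothing available explains these differences. The compounds shown leave open whether pyridin-3-yl, pyridin-4-yl or unsubstituted phenyl would behave like pyridin-2-yl. They also leave open what an amine or a carboxylic acid on this ring would do.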